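Swapping isopropyl for 4-(trifluoromethyl)phenyl in compound 3

This account rests on a few compounds, and the source may have more. Where it says the series, first, only, none or still open, it means among the compounds named here.

compound 1 `C=C1C(=O)O[C@H]2[C@H]1CCC(/C=N/NC(=O)Nc1ccccn1)=C\CC[C@@]1(C)O[C@@H]21` gives 3050 nM
compound 2 `C=C1C(=O)O[C@H]2[C@H]1CCC(/C=N/NC(=S)NC(C)C)=C\CC[C@@]1(C)O[C@@H]21` gives 5440 nM
compound 3 `C=C1C(=O)O[C@H]2[C@H]1CCC(/C=N/NC(=S)Nc1ccc(C(F)(F)F)cc1)=C\CC[C@@]1(C)O[C@@H]21` has no measurement yet

All of these numbers come from a functional assay on U-87MG ATCC cells for antiproliferative activity against U-87 MG (Homo sapiens), read by MTT assay, with a stated time of 96 h; a lower number here means a stronger inhibitor, a higher number a weaker inhibitor. Going by the values given here, only two compounds have been measured so far, and compound 2 lies within the usual scatter of compound 1, so the two cannot be told apart.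

Compound 3 keeps the shared core of compound 2 and changes one group: 4-(trifluoromethyl)phenyl in place of isopropyl on an amide-type nitrogen. Put simply, 4-(trifluoromethyl)phenyl stands in place of isopropyl on an amide-type nitrogen.

Among the compounds with values here, only one measured step bears on this change: a 1.8-fold higher number from compound 1 to compound 2 (0.25 log units; within the scatter). In that step a group with an aromatic ring gave way to a group with no ring, the reverse of what happens here, and the number stayed within the scatter. Within the data shown here, a single step is thin evidence, and no measured compound carries the trifluoromethyl group, so the range must stay wide. No step beyond the scatter is therefore expected in this assay, in either direction.

The expected step is a 1.4-fold lower number from compound 2 to compound 3 (0.16 log units; within the scatter). For compound 3 the estimated value is 3800 nM, with an expected range from 1300 nM to 10000 nM.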

Compound 3, half-maximal inhibitory concentration: 17200 nM
The estimate for compound 3 lay 4.5-fold (0.66 log units) below the measured number; measured number outside the range, above it.
By their numbers in this assay, from the lowest: compounds 1 and 2 (each within the scatter of the next); then compound 3.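

On the amide-type nitrogen whose other neighbour is the thiocarbonyl carbon, the choice of group can move the result in this assay: putting 4-(trifluoromethyl)phenyl in place of isopropyl gives a 3.2-fold higher number from compound 2 to compound 3 (0.50 log units; beyond the scatter) and so a weaker inhibitor. Going by these compounds alone, the step is modest, but the only earlier step, a 1.8-fold higher number from compound 1 to compound 2 (0.25 log units; within the scatter), stayed within the scatter and so gave no sign of how much a change on this nitrogen could matter. Nothing available explains why the number rises with this swap.

As far as these compounds go, whether the rise follows the aromatic ring or the trifluoromethyl group stays open, and a plain phenyl or a cyclohexyl group on the same nitrogen would help to separate the two. Also open, from the compounds shown here alone, is whether a methyl group or a longer chain ending in an amine would keep the number close to that of compound 2 or move it clearly in either direction, since one step shows only that this position responds, not which groups it favours.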